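From 3,4-difluorophenyl to 3-(trifluoromethyl)phenyl in compound 4

The source may hold more compounds than are shown below. What is called first, only, known or untested is meant among the compounds shown, and "the series" means these compounds.

Measured in a functional assay on A-375 cells (Homo sapiens) for antiproliferative activity; a lower number here means a stronger inhibitor, a higher number a weaker inhibitor:
compound 1 `O=C(Nc1ccc(-c2cscn2)cc1)C1CCCN(Cc2ccc(F)c(F)c2)C1`: 880 nM
compound 2 `O=C(Nc1ccc2scnc2c1)C1CCCN(Cc2ccc(F)c(F)c2)C1`: > 20000 nM (a limit of the assay, not a number)
compound 3 `O=C(Nc1ccc(-c2cscn2)cc1)[C@@H]1CCCN(Cc2ccc(F)c(F)c2)C1`: 6000 nM

Of the two true numbers in this assay, compound 1 holds the lower, and compound 3 is its nearest neighbour: a 6.8-fold higher number from compound 1 to compound 3 (0.83 log units; beyond the scatter). What separates these two is the fact that one of compounds 1 and 3 is drawn with a defined configuration and the other without, at the place where they differ. Compound 2 gives no number to compare, and it accounts for (the limit of > 20000 nM in this assay, at which 1 of the 3 values shown sits).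

Compound 4 `O=C(Nc1ccc(-c2cscn2)cc1)C1CCCN(Cc2cccc(C(F)(F)F)c2)C1` has not yet been measured. It keeps the core of compound 1 and changes one group: 3-(trifluoromethyl)phenyl in place of 3,4-difluorophenyl on a saturated chain carbon bound to an amine nitrogen in a ring. The 3-(trifluoromethyl)phenyl takes the place of 3,4-difluorophenyl on a saturated chain carbon bound to an amine nitrogen in a ring.

For the measured compounds named here, no measured step touches this group. Going by the values given here, the only step available, a 6.8-fold higher number from compound 1 to compound 3 (0.83 log units; beyond the scatter), is a change of another kind, so it offers no more than a rough sense of how far values move in this small set. A small step toward a higher number is therefore expected in this assay, and it may not exceed the scatter. The expected step is a 1.5-fold higher number from compound 1 to compound 4 (0.17 log units; within the scatter). Compound 4 is estimated at 1300 nM, with an expected range of 300 nM to 6000 nM.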

Compound 4, half-maximal inhibitory concentration: > 20000 nM
Compound 4 ended at the assay's limit; the forecaster's own chance of this, stated with the estimate: 10%; middle value at least 15-fold (1.18 log units) from the limit.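

In this assay, for the compounds shown here, replacing 3,4-difluorophenyl with 3-(trifluoromethyl)phenyl on a saturated chain carbon bound to an amine nitrogen in a ring gives an at least 22-fold higher number from compound 1 to compound 4 (1.35 log units; beyond the scatter), the first measured evidence that activity depends strongly on the group at this place. The value of compound 4 is a limit of the assay and not a number: the limit of > 20000 nM in this assay, at which 2 of the 4 values shown sit. The change is also narrow in what can be counted, since both groups contain one six-membered aromatic ring of carbon only, neither has hydrogen-bond donors or acceptors, and neither carries a net charge, so a swap that leaves these counts unchanged and adds only a few heavy atoms is enough to take compound 4 out of the measurable range.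

The compounds shown do not separate the arrival of the trifluoromethyl group from the loss of the 3,4-difluoro pattern, and so cannot tell which of the two matters. From the compounds shown here alone, whether a plain phenyl ring, a single fluorine, a chlorine or a methoxy group at this place would keep the activity of compound 1 remains open, as does the size of the true step, which the limit conceals.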